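The source may report more compounds than this note shows. Statements on the series, on what has been measured and on what is new or still open speak of the compounds shown alone.

- compound 1 `CCCNC(=C\C(=O)/C=C/c1ccc(O)c(OC)c1)/C=C/c1ccc(O)c(OC)c1`: > 25000 nM (a limit of the assay, not a number)
- compound 2 `C=CCNC(=C\C(=O)/C=C/c1ccc(O)c(OC)c1)/C=C/c1ccc(O)c(OC)c1`: 24600 nM
- compound 3 `CCC(C)NC(=C\C(=O)/C=C/c1ccc(OC(C)=O)c(OC)c1)/C=C/c1ccc(OC(C)=O)c(OC)c1`: > 25000 nM (a limit of the assay, not a number)

Among the compounds with values here, in a functional assay on HT-29 cells (Homo sapiens) for inhibition, read by sulforhodamine B assay, with a stated time of 72 h (on this read-out higher numbers stand for weaker inhibition and lower numbers for stronger inhibition), compound 2 gives 24600 nM, the only true number in this small set. Compound 1 and compound 3 stand at the limit of > 25000 nM in this assay, at which 2 of the 3 values shown sit. No number here therefore stands clearly apart from that limit.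

Compound 4 `CCCCNC(=C\C(=O)/C=C/c1ccc(O)c(OC)c1)/C=C/c1ccc(O)c(OC)c1` has not yet been measured. It carries a butyl group on the amine nitrogen where compound 2 carries an allyl group, so propyl replaces vinyl on a saturated chain carbon bound to an amine nitrogen: propyl in place of vinyl on a saturated chain carbon bound to an amine nitrogen.

Within the data shown here, one measured step bears on this change. Vinyl in place of ethyl at that same place gave an at least 1.0-fold lower number from compound 1 to compound 2 (0.00 log units; that floor lies within the scatter). Among the measured compounds shown here, with only that step to go on, no change beyond the scatter is expected in this assay, and compound 4 may well be reported only as a limit. The expected step is a 1.0-fold lower number from compound 2 to compound 4 (0.01 log units; within the scatter). For compound 4 the estimate is 24000 nM, with an expected range of 12000 nM to 40000 nM.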

Compound 4, half-maximal inhibitory concentration: 21200 nM
Compound 4: the middle estimate sits 1.1-fold (0.05 log units) above what was measured, and the stated range covers the measured number.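

In this assay, a saturated butyl group on the amine nitrogen matches the allyl group within the scatter, a 1.2-fold lower number from compound 2 to compound 4 (0.06 log units; within the scatter), so among these compounds the double bond in that chain is not needed to reach this level of inhibition. Compound 1 stands at > 25000 nM, which is a limit of the assay and not a number. Its step to the longer saturated chain, an at least 1.1-fold lower number from compound 1 to compound 4 (0.07 log units; that floor lies within the scatter), gives only a floor, so it cannot show whether the extra carbon matters.

From the compounds shown here alone, whether any group on the amine nitrogen can bring the number clearly down remains open, since these readings crowd the top of the range: the limit of > 25000 nM in this assay, at which 2 of the 4 values shown sit A much longer chain, a benzyl group or a chain ending in a carboxylic acid would be a sharper test of this position.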